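The source may report more compounds than this note shows. Statements on the series, on what has been measured and on what is new or still open speak of the compounds shown alone.

Working notes on the series. In an ADME assay on L6 cells (Rattus norvegicus) for cytotoxicity, read by resazurin assay, with a stated time of 72 h (a lower number here means a stronger inhibitor, a higher number a weaker inhibitor), compound 1 (`NC1CC2(N3CCCC3)CC(c3ccccc3)C1C(c1ccccc1)C2`) gives 38100 nM, compound 2 (`NC1CC2(N3CCCCC3)CC(c3ccccc3)C1C(c1ccccc1)C2`) gives 35000 nM and compound 3 (`CN(C)C12CC(N)C(C(c3ccccc3)C1)C(c1ccccc1)C2`) gives 40900 nM. Compound 2 stands level with the other two, since a 1.1-fold lower number from compound 1 to compound 2 (0.04 log units; within the scatter) and a 1.2-fold higher number from compound 2 to compound 3 (0.07 log units; within the scatter) both lie within the scatter, as does a 1.1-fold higher number from compound 1 to compound 3 (0.03 log units; within the scatter). Compound 4 (`O=C(CN1CCCC1)OC1CC2(N3CCCCC3)CC(c3ccccc3)C1C(c1ccccc1)C2`) departs from compound 2 at a different place: (((pyrrolidin-1-yl)methyl)carbonyl)oxy in place of amino on a saturated ring carbon. All measured steps exchange only the piperidin-1-yl, pyrrolidin-1-yl or dimethylamino group, so none tests the loss of amino, and they bear on this change only indirectly. With so flat a series, no step beyond the scatter is expected, and the estimated move is a 1.3-fold lower number from compound 2 to compound 4 (0.10 log units; within the scatter). Compound 4 is expected at 28000 nM, within an estimated range of 9000 nM to 80000 nM.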

Compound 4, half-maximal inhibitory concentration: 16400 nM
Compound 4: the middle estimate sits 1.7-fold (0.23 log units) above what was measured; the range from low to high includes it.
By their numbers in this assay, from the lowest: compound 4; then compounds 2, 1 and 3 (each within the scatter of the next).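

In this assay the exchange of amino for (((pyrrolidin-1-yl)methyl)carbonyl)oxy on this saturated ring carbon gives a 2.1-fold lower number from compound 2 to compound 4 (0.33 log units; beyond the scatter) and is the only step shown beyond the scatter, though a modest one. This position therefore moves the number where the piperidin-1-yl, pyrrolidin-1-yl and dimethylamino exchanges did not, even if only slightly. Nothing available explains the step. Going by these compounds, whether it follows from losing amino or from the entering chain stays open, and a hydroxy or acetyloxy group here would separate the two. Also open, on these data alone, is whether the change carries over to the pyrrolidin-1-yl and dimethylamino compounds.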